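Replacing One Phenyl Substituent on the Amine Nitrogen

The source may report more compounds than this note shows. Statements on the series, on what has been measured and on what is new or still open speak of the compounds shown alone.

Compound 1, `Cc1nc(-c2ccccc2)c(C(=O)N2CCN(c3ccccc3Cl)CC2)o1`, gives 124 nM.
Compound 2, `CC(C)(C)c1nc(-c2ccccc2F)c(C(=O)N2CCN(c3cccc(Cl)c3)CC2)o1`, gives > 1000 nM.

Both results come from a functional assay on HL-60 cells (Homo sapiens) for inhibition, read by MTT assay, with a stated time of 72 h; on this read-out lower numbers stand for stronger inhibition and higher numbers for weaker inhibition. Compound 1 holds the only actual number shown. The result for compound 2 is a limit of the assay and not a number, (the limit of > 1000 nM in this assay, at which 1 of the 2 values shown sits). Compound 3, `Cc1nc(-c2ccccc2)c(C(=O)N2CCN(c3cccc(C#N)c3)CC2)o1`, has not yet been tested; it differs from compound 1 by 3-cyanophenyl in place of 2-chlorophenyl on an amine nitrogen in a ring. Going by the values given here, no measured pair isolates this single change, and compound 2 differs from compound 1 in several places at once, so its limit says nothing specific about the group on the amine nitrogen. The step from compound 1 to compound 3 is expected to be a modest weakening, a 2.4-fold higher number from compound 1 to compound 3 (0.38 log units; beyond the scatter), at the edge of the usual scatter. Compound 3 is therefore estimated at 300 nM, with a plausible range from 100 nM to 1500 nM.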

Compound 3, half-maximal inhibitory concentration: 39.6 nM
Compound 3: middle estimate off by 7.6-fold (0.88 log units), on the high side; measured number below the stated range.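

Swapping 2-chlorophenyl for 3-cyanophenyl on the amine nitrogen, with the shared core left unchanged, gives a 3.1-fold lower number from compound 1 to compound 3 (0.50 log units; beyond the scatter) in this assay, so this position responds to a single change and can carry a nitrile with stronger inhibition than compound 1 shows. The swap alters two things at once, the kind of substituent on the phenyl ring and where it sits on that ring, so the step cannot be credited to either one alone. Nothing shown here explains why the number falls.

The compounds shown leave open whether 3-chlorophenyl or 2-cyanophenyl on the same core would separate those two changes. From the compounds shown here alone, how a methoxy group or an amine on this phenyl ring would behave also remains open.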